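This account rests on a few compounds, and the source may have more. Where it says the series, first, only, none or still open, it means among the compounds named here.

Measured compounds:
- compound 1 `COc1cc(/C=C/C(=O)/C=C(O)/C=C/c2ccc(OC(=O)[C@H](CCC(N)=O)NC(=O)OCc3ccccc3)c(OC)c2)ccc1OC(=O)[C@H](CCC(N)=O)NC(=O)OCc1ccccc1`: 45%
- compound 2 `COc1cc(/C=C/C(=O)/C=C(O)/C=C/c2ccc(OC(=O)C(C)NC(=O)OCc3ccccc3)c(OC)c2)ccc1OC(=O)C(C)NC(=O)OCc1ccccc1`: 97%
- compound 3 `COc1cc(/C=C/C(=O)/C=C(O)/C=C/c2ccc(OC(=O)C(C)NC(=O)OC(C)(C)C)c(OC)c2)ccc1OC(=O)C(C)NC(=O)OC(C)(C)C`: 25%

Of the compounds shown here, three sharing one core have been tested in a functional assay on the whole organism (strain Wistar) for inhibition, with Rattus norvegicus as the target, read by paw edema, with stated times of 1 h and 3 h, at a dose of 10 mg/kg by the intraperitoneal route; on this read-out higher numbers stand for more inhibition at the one dose given (going by the name of the read-out) and lower numbers for less inhibition. Compound 1 gives 45%, compound 2 gives 97% and compound 3 gives 25%. Compound 2 therefore stands highest of the three numbers; its nearest neighbour is compound 1, whose number lies a good way lower, beyond the usual scatter of this kind of measurement, and compound 3 lies lower still, also beyond the scatter.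

The next compound, compound 4 `COc1cc(/C=C/C(=O)/C=C(O)/C=C/c2ccc(OC(=O)[C@H](C)NC(=O)OCc3ccccc3)c(OC)c2)ccc1OC(=O)[C@H](C)NC(=O)OCc1ccccc1`, has not yet been measured in this assay. Its relation to compound 2 is this: the two compounds have the same atoms and bonds; at least one stereo element is drawn with a configuration in one of them and without one in the other: 2 of 5 stereo elements differ; a stereocentre at a saturated chain carbon is drawn without a configuration in compound 2 and S in compound 4; a stereocentre at a saturated chain carbon is drawn without a configuration in compound 2 and S in compound 4. Nothing leaves and nothing enters; the only difference is that the two stereocentres at saturated chain carbons, drawn without a configuration in compound 2, are drawn as S in compound 4.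

Since the atoms and bonds are the same and the two compounds differ only in whether a configuration is drawn, no step beyond the scatter is expected in this assay in either direction. Compound 4 is accordingly expected to give about 90%, within a range from 75% to 100%, so that the estimated step of a number 7 percentage points lower from compound 2 to compound 4 (within the scatter) stays within the scatter.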

Compound 4, a percentage reported as inhibition, in the whole organism at one dose (the size of the read-out at that dose, not a potency): 22%
Compound 4: the middle estimate sits 68 percentage points above what was measured; the whole stated range lies above it.
By their numbers in this assay, from the lowest: compounds 4 and 3 (each within the scatter of the next); then compound 1; then compound 2.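

In this assay, for the compounds shown here, this pair gives the first step between two compounds that differ in one place, and it is a large one: a number 75 percentage points lower from compound 2 to compound 4 (beyond the scatter). Nothing leaves and nothing enters, so no change of group can account for this step, and it can be traced only to the two stereocentres at saturated chain carbons, because the one difference left between the structures is: the fact that one of compounds 2 and 4 is drawn with a defined configuration and the other without, at the place where they differ. For this pair, then, whether a configuration is defined at these carbons is not a mere detail of the drawing, even though the atoms and bonds are the same.

The compounds shown leave open what the undefined drawing of compound 2 stands for in the material tested, and how the R configuration at these two stereocentres would read out in this assay. They also leave open whether a longer chain on those same saturated chain carbons would show the same sensitivity to configuration.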